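The source may hold more compounds than are shown below. What is called first, only, known or untested is meant among the compounds shown, and "the series" means these compounds.

Two compounds share one core and differ only in the aromatic ring attached to a nitrogen. Compound 1 `Cc1n[nH]c2ccc(-c3nc4cnc(N5CCN(C)CC5)cn4c3Nc3ccccc3F)cc12` carries a 2-fluorophenyl there, and in a functional assay on MV4-11 cells (Homo sapiens) for inhibition, with a stated time of 120 h, tested at 10 uM (on this read-out higher numbers stand for more inhibition at the one concentration tested (going by the name of the read-out) and lower numbers for less inhibition), compound 1 gives 0%. Compound 2 `Cc1n[nH]c2ccc(-c3nc4cnc(N5CCN(C)CC5)cn4c3Nc3ccc(Br)cc3)cc12` carries a 4-bromophenyl instead, and in this assay compound 2 gives 83%. Among the compounds with values here, that single swap produced a number 83 percentage points higher from compound 1 to compound 2 (beyond the scatter), so compound 2 stands as the higher of the two numbers, with compound 1 as its only neighbour, far below it.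

Compound 3 `Cc1n[nH]c2ccc(-c3nc4cnc(N5CCN(C)CC5)cn4c3Nc3ccc(I)cc3)cc12` keeps everything in compound 2 except one atom: iodo in place of bromo on an aromatic carbon. Within the data shown here, the only measured step, from compound 1 to compound 2, changed both the kind of halogen and where it sits on the ring, a far bigger change than the one here; it shows a halogen para to a large group going with strong inhibition, but it does not separate bromo from iodo. With nothing that isolates this swap, the expected step is a number 3 percentage points lower from compound 2 to compound 3 (within the scatter), within the usual scatter. Compound 3 is therefore estimated at 80%, with a likely range from 55% to 95%.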

Compound 3, a percentage reported as inhibition, at one concentration (the size of the read-out at that concentration, not a potency): 0%
Compound 3: middle estimate off by 80 percentage points, on the high side; measured number outside the range, below it.
By their numbers in this assay, from the lowest: compounds 1 and 3 (each within the scatter of the next); then compound 2.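

Swapping one halogen atom for another at this position on the aromatic ring is not a minor edit: in this assay, iodo in place of bromo gives a number 83 percentage points lower from compound 2 to compound 3 (beyond the scatter) and removes all of the inhibition seen with the bromo compound. The earlier link between a halogen at this place and strong inhibition therefore holds only for compound 2, and compound 3 goes against it, with 4-iodophenyl in place of 2-fluorophenyl giving no change at the digits printed from compound 1 to compound 3 (within the scatter) on the shared core. Nothing available here explains why two such closely related groups part so sharply.

The compounds shown leave open how a 4-chlorophenyl, a 4-methoxyphenyl or an unsubstituted phenyl would read in this assay, so it cannot yet be told whether bromo is a rare exception or iodo is. They also leave open how compound 2 behaves at other concentrations, as a single reading at one concentration gives the size of the effect there and not a potency.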